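Swapping a Fluorophenyl for a Hydroxypentyl

A few compounds are considered here, and "the series" means these few. Any claim that something is new, unique, unknown or untested is made for them only; others in the source may bear on it.

Of the compounds shown here, two have been measured in an ADME assay on HeLa cells (Homo sapiens) for cytotoxicity, read by sulforhodamine B assay, with a stated time of 48 h, tested at 10 uM; a lower number here means less inhibition, a higher number more inhibition at the concentration tested (going by the name of the read-out). Compound 1 `CCOC(=O)c1cn(C(c2ccccc2)c2cc3cc(Br)ccc3nc2OC)nn1` gives -3.67%, and compound 2 `COc1nc2ccc(Br)cc2cc1C(c1ccccc1)n1cc(-c2ccc(F)cc2)nn1` gives 4.27%. Going by the values given here, the only measured step, a number 7.9 percentage points higher from compound 1 to compound 2 (within the scatter), changes a different group and stays within the scatter, so the two numbers cannot be told apart, and compound 2 cannot be called more or less cytotoxic than compound 1.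

Compound 3 `COc1nc2ccc(Br)cc2cc1C(c1ccccc1)n1cc(CCCCCO)nn1` differs from compound 2 in one place: 5-hydroxypentyl in place of 4-fluorophenyl on an aromatic carbon. Among the compounds with values here, no measured step touches a 5-hydroxypentyl group, and the one step available, from an ethoxycarbonyl to a 4-fluorophenyl, changed nothing beyond the scatter. There is therefore no ground to expect compound 3 to move away from compound 2 beyond the scatter in this assay, and the expected step is a number 2.3 percentage points lower from compound 2 to compound 3 (within the scatter). Compound 3 is estimated at 2%, within a range from -10% to 14%.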

Compound 3, a percentage reported as inhibition, at one concentration (the size of the read-out at that concentration, not a potency): 1.08%
For compound 3 the middle estimate is 0.9 percentage points above the measured one, and the stated range covers the measured number.
By their numbers in this assay, from the lowest: compounds 1, 3 and 2 (each within the scatter of the next).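

In this assay, putting 5-hydroxypentyl in place of 4-fluorophenyl on this aromatic carbon of the five-membered ring gives a number 3.2 percentage points lower from compound 2 to compound 3 (within the scatter), and putting it in place of ethoxycarbonyl gives a number 4.8 percentage points higher from compound 1 to compound 3 (within the scatter). This position therefore now holds an open chain with no ring and a hydrogen-bond donor, as well as the two earlier groups, and the read-out cannot tell the three compounds apart. No outside information bears on why these numbers stay together.

Going by these compounds, whether an amine, a carboxylic acid or a longer chain on this carbon would give a number beyond the scatter stays open. On these data alone, it is also open whether a change elsewhere on the shared core would do so.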